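Benzylsulfanyl to Propyl: An Expected Loss of Potency

A few compounds are considered here, and "the series" means these few. Any claim that something is new, unique, unknown or untested is made for them only; others in the source may bear on it.

Of the compounds shown here, two with a shared core have been measured in a functional assay (spleen, spleen) for activation, with Mus musculus as the target; on this read-out higher numbers stand for an effect only at larger amounts of compound and lower numbers for an effect already at smaller amounts. Among the compounds with values here, compound 1, `Nc1nc(SCc2ccccc2)nc2c1nc(O)n2Cc1ccccc1`, gives 0.1 uM in this assay, and this is the only plain number reported. Compound 2, `Nc1ncnc2c1nc(O)n2C1CCCC1`, reaches only the limit > 10 uM in this assay, so no number is known for it. Within the data shown here, compound 1 therefore stands as the single compound with a measured concentration, while the limit of > 10 uM in this assay, at which 1 of the 2 values shown sits, marks where compound 2 sits.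

Compound 3, `CCCc1nc(N)c2nc(O)n(Cc3ccccc3)c2n1`, has not yet been measured. It differs from compound 1 in one place: propyl in place of benzylsulfanyl on an aromatic carbon. Among the measured compounds shown here, no measured pair shows this kind of exchange, so the size of the step can only be expected rather than read from the data. The benzylsulfanyl group brings an aromatic ring and a hydrogen-bond acceptor that propyl does not, and the step from compound 1 to compound 3 is expected to be a loss of potency beyond the usual scatter, estimated as a 10-fold higher number from compound 1 to compound 3 (1.00 log units; beyond the scatter). Compound 3 is accordingly expected to need about 1 uM in this assay, within a range from 0.2 uM to 5 uM.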

Compound 3, minimum effective concentration: 1 uM
Compound 3: the middle estimate sits on the measured number at the digits printed, and the stated range covers the measured number.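

Moving from benzylsulfanyl to propyl on the aromatic carbon between two ring nitrogen atoms gives a 10-fold higher number from compound 1 to compound 3 (1.00 log units; beyond the scatter), so in this assay the group at this position clearly affects how much compound is needed. The step also shows that benzylsulfanyl is not essential for activity: compound 3, with its short open chain, still gives 1 uM, a plain number rather than a limit. Nothing measured here explains the step, so which part of the lost group matters remains unknown.

The exchange removes the sulfur, the six-membered aromatic ring and several carbon atoms all at once, so the compounds shown cannot separate their contributions: a propylsulfanyl group would keep the sulfur without the ring, while a phenethyl group would keep the ring without the sulfur. From the compounds shown here alone, it also remains open how this position responds to a longer chain such as hexyl, or to a different kind of group such as an amine, and whether any of these would bring the number back towards that of compound 1.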